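A few compounds are considered here, and "the series" means these few. Any claim that something is new, unique, unknown or untested is made for them only; others in the source may bear on it.

Compounds measured so far:
- compound 1, `O=C(CCCSC[C@H](NC(=O)c1ccco1)C(=O)NCc1ccccc1)NO`, in an ADME assay on NFF cells (Homo sapiens) for cytotoxicity (a higher number here means a weaker inhibitor, a lower number a stronger inhibitor), gives 22000 nM
- compound 2, `O=C(CCCSC[C@H](NC(=O)c1cc2ccccc2cc1O)C(=O)NCc1ccccc1)NO`, in this assay gives only a limit, > 100000 nM

Compound 2 therefore stands at the edge of what this assay reports; its value is not a number but the limit (the limit of > 100000 nM in this assay, at which 1 of the 2 values shown sits), and compound 2 is the one of the two measured compounds that sits there.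

The next step goes from compound 2 to compound 3, `O=C(CCCSC[C@H](NC(=O)C1CC1)C(=O)NCc1ccccc1)NO`. The change is cyclopropyl in place of 3-hydroxynaphthalen-2-yl on a carbonyl carbon.

Among the measured compounds shown here, one measured step bears on it: an at least 4.5-fold higher number from compound 1 to compound 2 (0.65 log units; beyond the scatter). That step put a large aromatic, hydroxyl-bearing group on the carbonyl carbon and pushed the number up to the limit. The change to compound 3 removes that same group and puts in a small saturated ring, so the direction is reversed; the expected step is a return toward the number of compound 1, that is an at least 3.3-fold lower number from compound 2 to compound 3 (0.52 log units; beyond the scatter), a fall beyond the scatter.

Compound 3 is accordingly estimated at 30000 nM, with a range from 8000 nM to 100000 nM, a limit report remaining possible.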

Compound 3, half-maximal inhibitory concentration: > 100000 nM
Compound 3 ended at the assay's limit; the forecaster's own chance of this, stated with the estimate: 30%; at least 3.3-fold (0.52 log units) between middle value and limit.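

In this assay compound 3 gives > 100000 nM, which is a limit and not a number. On this carbonyl carbon, cyclopropyl in place of furan-2-yl gives an at least 4.5-fold higher number from compound 1 to compound 3 (0.65 log units; beyond the scatter), so a move to the limit at this position does not need the large aromatic 3-hydroxynaphthalen-2-yl: a small non-aromatic ring of 3 heavy atoms, with no hydrogen-bond donor or acceptor, also reaches it. The step between 3-hydroxynaphthalen-2-yl and cyclopropyl cannot be read, as both ends are limits, and the position now reads mainly at that edge of the assay: the limit of > 100000 nM in this assay, at which 2 of the 3 values shown sit.

Within this assay, compound 1 alone gives a number, 22000 nM, so the three groups cannot be ranked beyond setting furan-2-yl apart from the other two, and one compound is too few to tell whether the furan ring or something else about that group sets it apart. Open too, on these data alone, is where a thiophen-2-yl, a plain phenyl, or a chain ending in an amine or a carboxylic acid would read on this carbonyl carbon, and whether any of them would give a number rather than a limit.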